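The source may report more compounds than this note shows. Statements on the series, on what has been measured and on what is new or still open speak of the compounds shown alone.

Working notes on the series. Compound 1 `CN1CCN(c2nc(-c3ccc(Cl)c(Cl)c3)nc3[nH]cnc23)CC1` gives 39.8 nM in an assay on cells for displacement of a labelled ligand from adenosine receptor A3 (Homo sapiens), read by scintillation counting and radioligand binding, with a stated time of 180 min; on this read-out higher numbers stand for weaker inhibition and lower numbers for stronger inhibition. Compound 2 `CN1CCN(c2nc(-c3cccc(Cl)c3)nc3[nH]cnc23)CC1` gives 100 nM in this assay, and the step is a 2.5-fold higher number from compound 1 to compound 2 (0.40 log units; beyond the scatter). Compound 3 `Clc1ccc(-c2nc(N3CCCCC3)c3nc[nH]c3n2)cc1Cl` gives 79.4 nM in this assay, the second highest of the three numbers, reached by a 2.0-fold higher number from compound 1 to compound 3 (0.30 log units; within the scatter). Compound 4 `Clc1ccc(-c2nc(N3CCCCC3)c3nc[nH]c3n2)cc1` is not yet measured. The change from compound 3 is hydrogen in place of chloro on an aromatic carbon. Among the compounds with values here, the one measured step that bears on it, the step from compound 1 to compound 2, is the same replacement on the other amine and gave a modest rise in the number. A similar shift upward is therefore expected here, a 2.5-fold higher number from compound 3 to compound 4 (0.40 log units; beyond the scatter). The estimate for compound 4 is 200 nM, expected between 100 nM and 400 nM.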

Compound 4, inhibition constant: 7.94 nM
Compound 4: middle estimate off by 25-fold (1.40 log units), on the high side; the measured number lies below the stated range.
By their numbers in this assay, from the lowest: compound 4; then compounds 1, 3 and 2 (each within the scatter of the next, the first and the last beyond it).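

Hydrogen in place of the chloro meta to a large group gives a 10-fold lower number from compound 3 to compound 4 (1.00 log units; beyond the scatter), so losing a chloro group does not always raise the number in this assay. The step to compound 2 removes the other chloro of the pair and sits on a different amine, and the two steps run in opposite directions: the same change on two cores in this assay, a 2.5-fold higher number (0.40 log units; beyond the scatter) from compound 1 to compound 2 and a 10-fold lower number (1.00 log units; beyond the scatter) from compound 3 to compound 4, 25-fold (1.40 log units) apart, beyond the scatter of two such steps

On these data alone, compound 2 and compound 4 differ in both the amine and the place of the remaining chloro, so which of the two sets the direction stays open. Also open, as far as these compounds go, is how a fluoro, methyl or methoxy group at this position would compare with hydrogen.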